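The source may report more compounds than this note shows. Statements on the series, on what has been measured and on what is new or still open speak of the compounds shown alone.

Measured in a functional assay (Saphenous vein) for binding affinity, with Oryctolagus cuniculus as the target; on this read-out higher numbers stand for weaker binding and lower numbers for tighter binding:
Compound 1 `CN(C)[C@H]1C[C@H](c2c[nH]c3ccc(C(=O)NCc4ccccc4)cc32)C1` gives 1260 nM
Compound 2 `Cc1noc(Cc2ccc3[nH]cc([C@H]4C[C@H](N(C)C)C4)c3c2)n1` gives 7590 nM
Compound 3 `Cc1nc(Cc2ccc3[nH]cc([C@H]4C[C@H](N(C)C)C4)c3c2)n[nH]1` gives 6610 nM

Compound 3 stands level with compound 2 within the scatter, and its number is higher than that of compound 1. The move to compound 4 `CN(C)[C@H]1C[C@H](c2c[nH]c3ccc(CC(N)=O)cc32)C1` is carbamoyl in place of 5-methyl-1H-1,2,4-triazol-3-yl on a saturated chain carbon bound to an aromatic carbon. Among the measured compounds shown here, one measured step bears on it, a 1.1-fold lower number from compound 2 to compound 3 (0.06 log units; within the scatter), an exchange of one ring for another at that same place. For the measured compounds named here, no measured step replaces that ring with an open group, so the guide is loose. In this assay only a small shift toward lower numbers is expected, with no change beyond the scatter, and the expected step is a 1.9-fold lower number from compound 3 to compound 4 (0.28 log units; within the scatter). For compound 4 the estimate is 3500 nM, with an expected range of 1000 nM to 10000 nM.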

Compound 4, dissociation constant: 16600 nM
Compound 4: the middle estimate sits 4.7-fold (0.68 log units) below what was measured; the whole stated range lies below it.
By their numbers in this assay, from the lowest: compound 1; then compounds 3 and 2 (each within the scatter of the next); then compound 4.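

In this assay, exchanging one ring for another at this place had left the number level, but the open carbamoyl group gives a 2.5-fold higher number from compound 3 to compound 4 (0.40 log units; beyond the scatter) and a 2.2-fold higher number from compound 2 to compound 4 (0.34 log units; beyond the scatter), both modest. Among these compounds, then, a saturated chain carbon bound to an aromatic carbon binds less tightly when it carries carbamoyl than when it carries either ring. Nothing measured here explains this difference. The compounds shown do not separate the loss of the ring from the drop in group size. On these data alone, how a carboxylic acid or a longer chain ending in carbamoyl would read at this place remains open.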